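Compound 1 to compound 4: replacing 3,4-dimethoxyphenyl

The source may hold more compounds than are shown below. What is called first, only, known or untested is meant among the compounds shown, and "the series" means these compounds.

Measured in a functional assay on SiHa cells (Homo sapiens) for inhibition, read by sulforhodamine B assay; a lower number here means a stronger inhibitor of growth, a higher number a weaker inhibitor of growth:
- compound 1 `COc1ccc(-c2ccc(-c3ccc(-c4nc5cc(C)ccc5[nH]4)cc3)cc2)cc1OC`: 3510 nM
- compound 2 `COc1ccc(-c2ccc(-c3ccc(-c4nc5ccccc5[nH]4)cc3)cc2)cc1OC`: 6200 nM
- compound 3 `COc1ccc(-c2ccc(-c3ccc(-c4nc5c(O)cccc5[nH]4)cc3)cc2)cc1OC`: 1110 nM

Compound 1 stands within the scatter of its nearest neighbour, with a 1.8-fold higher number from compound 1 to compound 2 (0.25 log units; within the scatter), while the step to the lowest number is a 3.2-fold lower number from compound 1 to compound 3 (0.50 log units; beyond the scatter). The next compound is compound 4 `Cc1ccc2[nH]c(-c3ccc(-c4ccc(-c5ccc(C(F)(F)F)cc5)cc4)cc3)nc2c1`, which carries the change (4-(trifluoromethyl)phenyl in place of 3,4-dimethoxyphenyl on an aromatic carbon). Within the data shown here, no measured step touches this group, since all three leave 3,4-dimethoxyphenyl in place. They bear on it only as a guide to size, and a 5.6-fold lower number from compound 2 to compound 3 (0.75 log units; beyond the scatter) is modest. From the compounds shown here alone, the direction remains unknown, so no change beyond the scatter is expected. The estimated step is a 1.1-fold higher number from compound 1 to compound 4 (0.06 log units; within the scatter). For compound 4 the expected value is 4000 nM, with an estimated range of 1200 nM to 13000 nM.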

Compound 4, concentration for 50% growth inhibition: 33200 nM
Compound 4: middle estimate off by 8.3-fold (0.92 log units), on the low side; measured number above the stated range.
By their numbers in this assay, from the lowest: compound 3; then compounds 1 and 2 (each within the scatter of the next); then compound 4.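

In this assay, among these compounds, the first change at this position gives a 9.5-fold higher number from compound 1 to compound 4 (0.98 log units; beyond the scatter), so 4-(trifluoromethyl)phenyl in place of 3,4-dimethoxyphenyl weakens growth inhibition beyond the scatter. The earlier steps shown here all left this group in place, and this step shows that the result also depends on this position. Nothing at hand accounts for the rise.

From the compounds shown here alone, whether the rise follows from losing the methoxy groups or from gaining trifluoromethyl stays open, since the two changes come together. A single methoxy group or an amine on this ring could separate them.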